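The compounds below may be only part of what the source reports. "The series", "measured", "known", "first", "only" and "open" are said of these compounds alone.

Measured so far:
compound 1, `Fc1cc(Cl)ccc1-c1ccc(Cn2nnc3ccccc32)cn1`: 3.4 mL/min/g
compound 2, `Fc1cc(Cl)ccc1-c1ccc(Cn2nnc3c(C(F)(F)F)cccc32)cn1`: 0.1 mL/min/g

Both were tested in an ADME assay on microsomes from liver (Mus musculus, strain NMRI) for metabolic stability, tested at 2.5 uM; a higher number here means faster removal of the compound, a lower number slower removal. In this assay compound 1 gives 3.4 mL/min/g, while compound 2 gives 0.1 mL/min/g, the lowest of the two numbers. For the measured compounds named here, the only step measured so far, a 34-fold lower number from compound 1 to compound 2 (1.53 log units; beyond the scatter), was a large one.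

Compound 3, `Fc1cc(Cl)ccc1-c1ccc(Cn2nnc3c(Br)cccc32)cn1`, differs from compound 2 in a single place: bromo in place of trifluoromethyl on an aromatic carbon.

Going by the values given here, the one measured step bears on this change only indirectly: it shows what putting trifluoromethyl in place of hydrogen did, whereas compound 3 carries bromo at that carbon, neither hydrogen nor trifluoromethyl. The expectation is therefore a number lying between those of compound 1 and compound 2, nearer to compound 2, so a moderate rise beyond the scatter is expected, a 5.0-fold higher number from compound 2 to compound 3 (0.70 log units; beyond the scatter). Compound 3 is estimated at 0.5 mL/min/g, with a range from 0.15 mL/min/g to 1.6 mL/min/g.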

Compound 3, intrinsic clearance in a liver preparation (reported as CLH), per the amount of preparation that the assay uses: 3.8 mL/min/g
Beside the measured number, compound 3's estimate is 7.6-fold (0.88 log units) below it, and the stated range ends below it.
By their numbers in this assay, from the lowest: compound 2; then compounds 1 and 3 (each within the scatter of the next).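

In this assay, the change to bromo gives a 38-fold higher number from compound 2 to compound 3 (1.58 log units; beyond the scatter) and the change from hydrogen to bromo gives a 1.1-fold higher number from compound 1 to compound 3 (0.05 log units; within the scatter), so compound 1 and compound 3 cannot be told apart. The earlier step alone left room for the idea that any added group on this aromatic carbon would lower the number, but compound 3 shows that filling the carbon is not enough: of the three groups shown here, only trifluoromethyl goes with the low number. No measurement available here explains why trifluoromethyl and bromo differ so sharply.

As far as these compounds go, whether a nitrile, a methoxy group or an amine on this carbon would behave like trifluoromethyl or like bromo remains open. So does whether trifluoromethyl would have the same effect on another carbon of this ring.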